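The source may hold more compounds than are shown below. What is called first, only, known or untested is meant among the compounds shown, and "the series" means these compounds.

Measured so far in a functional assay on Raji cells (Homo sapiens) for antiproliferative activity, read by CCK-8 assay, with a stated time of 24 h; a higher number here means a weaker inhibitor, a lower number a stronger inhibitor:

Compound 1 `C=CC(=O)Nc1cc(Nc2ncnc(Nc3ccc(C(=O)N4CCCCC4)cc3)n2)ccc1C` gives 30600 nM.
Compound 2 `C=CC(=O)Nc1cccc(Nc2ncnc(Nc3ccc(-c4cccnc4)cc3)n2)c1` gives 12400 nM.
Compound 3 `C=CC(=O)Nc1cccc(Nc2ncnc(Nc3ccc(C(=O)Nc4ccccn4)cc3)n2)c1` gives 15600 nM.

Compound 3 sits second highest of the three numbers. Its nearest neighbour is compound 2, whose value is within the scatter of it, and even compound 1, the furthest, differs from compound 3 by no more than the scatter allows, so none of the three can be called stronger or weaker than another on these numbers.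

Compound 4 `C=CC(=O)Nc1cccc(Nc2ncnc(Nc3ccc(-c4ccc(C)nc4)cc3)n2)c1` has not yet been measured. It differs from compound 3 in one place: 6-methylpyridin-3-yl in place of (pyridin-2-yl)carbamoyl on an aromatic carbon. Going by the values given here, the only measured step that touches this part of the molecule is the one from compound 2 to compound 3, a 1.3-fold higher number from compound 2 to compound 3 (0.10 log units; within the scatter), which swapped a pyridine ring for a carbamoyl-linked pyridine without moving the number beyond the scatter. Going from compound 3 to compound 4 largely reverses that swap, with a methyl added to the returning ring, so no shift beyond the scatter is expected in this assay. The step from compound 3 to compound 4 is therefore estimated at a 1.4-fold lower number from compound 3 to compound 4 (0.15 log units; within the scatter). Compound 4 is expected to give 11000 nM, in a range from 4000 nM to 30000 nM.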

Compound 4, half-maximal inhibitory concentration: 13800 nM
Estimate against measurement, compound 4: 1.3-fold (0.10 log units) below; low and high end bracket the measured number.
By their numbers in this assay, from the lowest: compounds 2, 4, 3 and 1 (each within the scatter of the next, the first and the last beyond it).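

In this assay the methyl group gets its first direct reading: adding it to the pyridine ring gives a 1.1-fold higher number from compound 2 to compound 4 (0.05 log units; within the scatter) and so leaves the number within the scatter. The other new step, a 1.1-fold lower number from compound 3 to compound 4 (0.05 log units; within the scatter) for 6-methylpyridin-3-yl in place of (pyridin-2-yl)carbamoyl, shows that this exchange is also within the scatter, even though the group that leaves carries a hydrogen-bond donor and the group that enters carries none. No measured evidence is available to explain these results.

The compounds shown leave open whether an amine, a carboxylic acid or a longer chain on this aromatic carbon would move the number beyond the scatter. They also leave open what an ethyl or methoxy group would do in place of the methyl on the pyridine ring.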